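Swapping the group on the ring nitrogen of compound 1

The source may hold more compounds than are shown below. What is called first, only, known or untested is meant among the compounds shown, and "the series" means these compounds.

Compound 1 `Cc1ccccc1-c1nn(Cc2ccc(F)cc2)cc1CNCCN1CCN(C)CC1` is one of three compounds sharing a core that have been tested in an ADME assay on Huh-7 cells (Homo sapiens) for cytotoxicity; on this read-out higher numbers stand for lower toxicity in this test and lower numbers for higher toxicity in this test. In this assay compound 1 gives > 20000 nM, which is a limit of the assay and not a number. Compound 2 `COC(=O)c1ccc(-c2nn(-c3ccc(F)cc3F)cc2CNCCN2CCN(C)CC2)cc1` likewise reaches only a limit in this assay, namely > 20000 nM. Compound 3 `CN1CCN(CCNCc2cn(-c3ccc(F)cc3F)nc2-c2ccc(C(F)(F)F)cc2)CC1` gives 20000 nM in this assay. Among the measured compounds shown here, the single measured step, a number no higher from compound 2 to compound 3 (the limit leaves the size open), is of unreadable size, and it concerns a different place on the core than the change considered here. Compound 1 thus stands at the limit of > 20000 nM in this assay, at which 2 of the 3 values shown sit, alongside compound 2, and no measured number separates it from the other two.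

Compound 4 `Cc1ccccc1-c1nn(-c2cccc(Cl)c2)cc1CNCCN1CCN(C)CC1` differs from compound 1 by 3-chlorophenyl in place of 4-fluorobenzyl on an aromatic nitrogen. For the measured compounds named here, no measured step touches the group on the aromatic nitrogen, so the only guidance is that every value shown either is a limit or sits at the same figure. Because compound 1 and compound 2 both rest at the limit of > 20000 nM in this assay, at which 2 of the 3 values shown sit, compound 4 is expected to show no step beyond the scatter, an expected step of a number no higher from compound 1 to compound 4 (the limit leaves the size open). Compound 4 is therefore estimated at 20000 nM, with a range from 10000 nM to 40000 nM, and most likely again only as a limit.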

Compound 4, half-maximal cytotoxic concentration: 16000 nM
Estimate against measurement, compound 4: 1.3-fold (0.10 log units) above; measured number inside the range.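

Replacing 4-fluorobenzyl by 3-chlorophenyl on the aromatic nitrogen gives, in this assay, an at least 1.2-fold lower number from compound 1 to compound 4 (0.09 log units; that floor lies within the scatter), and this is the first step shown that touches this position. As far as these compounds go, compound 4 thus gives a readable number with a group on this nitrogen, but the step has only a floor, so its true size stays open and the result shows no step beyond the scatter at this position. Compound 1, the other end of the step, stays at a limit of the assay and not a number: the limit of > 20000 nM in this assay, at which 2 of the 4 values shown sit.

The change swaps the benzyl for a phenyl and the fluorine for a chlorine in one move, with 8 heavy atoms leaving and 7 entering, so the compounds shown cannot tell these two parts apart; 3-chlorobenzyl or 4-fluorophenyl on the same nitrogen, with the 2-methylphenyl group kept, would separate them. They also leave open how far the number would move with a ring carrying an amine or a carboxylic acid at this position, or with a longer chain between the nitrogen and the ring.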